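From chloro to bromo on a shared core

A few compounds are considered here, and "the series" means these few. Any claim that something is new, unique, unknown or untested is made for them only; others in the source may bear on it.

Compound 1 `O=C1O/C(=C\Cn2cc(C(F)(F)F)c(=O)[nH]c2=O)C(OCc2ccccc2)=C1OCc1ccccc1` gives 40000 nM in a functional assay on HEp-2 cells (Homo sapiens) for inhibition; a lower number here means a stronger inhibitor, a higher number a weaker inhibitor
Compound 2 `O=C1O/C(=C\Cn2cc(Cl)c(=O)[nH]c2=O)C(OCc2ccccc2)=C1OCc1ccccc1` gives 20000 nM in this assay

Going by the values given here, only two compounds have been measured so far, so there is little to compare. Among the compounds with values here, compound 2 stands at 20000 nM and cannot be told apart from compound 1, the only other compound measured, since the two values lie within the usual scatter of repeated measurements.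

Compound 3 `O=C1O/C(=C\Cn2cc(Br)c(=O)[nH]c2=O)C(OCc2ccccc2)=C1OCc1ccccc1` keeps the shared core and changes a single group (bromo in place of chloro on an aromatic carbon), with bromo in place of chloro on an aromatic carbon. Within the data shown here, one measured step bears on this change. It also swaps one group on an aromatic carbon for another, chloro in place of trifluoromethyl, and it amounts to a 2.0-fold lower number from compound 1 to compound 2 (0.30 log units; within the scatter) and lies within the scatter. On that single step, no change beyond the scatter is expected in this assay and no direction can be favoured. The estimated change is no change at the digits printed from compound 2 to compound 3 (within the scatter) and this rests on thin evidence. The estimate for compound 3 is 20000 nM and 9000 nM to 45000 nM is its expected range.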

Compound 3, half-maximal inhibitory concentration: 90000 nM
Compound 3: the middle estimate sits 4.5-fold (0.65 log units) below what was measured; measured number outside the range, above it.
By their numbers in this assay, from the lowest: compounds 2 and 1 (each within the scatter of the next); then compound 3.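

In this assay, this position turns out to respond to a change of group: bromo in place of chloro, one heavy atom exchanged for one heavy atom with no change in the counted hydrogen-bond donors or acceptors, gives a 4.5-fold higher number from compound 2 to compound 3 (0.65 log units; beyond the scatter). Bromo in place of trifluoromethyl points the same way, with a 2.3-fold higher number from compound 1 to compound 3 (0.35 log units; beyond the scatter), which makes compound 3 the weakest inhibitor of the three, even though chloro and trifluoromethyl could not be told apart on this aromatic carbon. No measurement is available to explain why bromo stands apart from the other two groups.

The compounds shown leave open how this position would respond to groups of a different kind, such as a methyl, a nitrile or an amine, and whether a fluoro would fall with chloro or with bromo. They also leave open whether the step from chloro to bromo would be the same size on a different core, since so far it rests on a single pair of compounds.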